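Capping a Piperazine Nitrogen in an Inactive Triazole Series

This account rests on a few compounds, and the source may have more. Where it says the series, first, only, none or still open, it means among the compounds named here.

compound 1 `Cc1cc(=O)oc2cc(OCCn3cc(CSC(=S)N4CCN(C(=O)OC(C)(C)C)CC4)nn3)ccc12` — > 128000 nM
compound 2 `COc1cc(Cn2cc(CSC(=S)N3CCNCC3)nn2)cc(OC)c1OC` — > 128000 nM
compound 3 `S=C(SCc1cn(Cc2ccc(Cl)cc2)nn1)N1CCNCC1` — > 128000 nM

Of the compounds shown here, three have been tested in a functional assay on ECa-109 cells (Homo sapiens) for inhibition, read by MTT assay, with a stated time of 72 h; a lower number here means a stronger inhibitor, a higher number a weaker inhibitor. Compound 1 returned only a limit of the assay, > 128000 nM. Compound 2 likewise returned only a limit, > 128000 nM. Compound 3 also returned only a limit, > 128000 nM. Compound 2 therefore stands nowhere in particular among the numbers shown: due to the limit of > 128000 nM in this assay, at which 3 of the 3 values shown sit, no compound can be ranked against another, and no step between measured compounds can be drawn.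

Compound 4 `COc1cc(Cn2cc(CSC(=S)N3CCN(C(=O)OCc4ccccc4)CC3)nn2)cc(OC)c1OC` is the next candidate. It differs from compound 2 in one place: benzyloxycarbonyl in place of hydrogen on an amine nitrogen in a ring. Compound 1 already carries a carbamate on the same ring nitrogen and gave only a limit, so the shown data offer no sign that capping this nitrogen moves the read-out. The step from compound 2 to compound 4 is expected to be none beyond the scatter, a step that the limit leaves unreadable from compound 2 to compound 4. Compound 4 is accordingly estimated at 160000 nM, within 60000 nM to 450000 nM, and most likely to be reported again as a limit.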

Compound 4, half-maximal inhibitory concentration: > 128000 nM
Compound 4 was reported as a limit; the forecaster's own chance of this, stated with the estimate: 80%; the middle value does not contradict the limit.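

Within the data shown here, compound 2 and compound 4 each returned only a limit, so no step between them can be read: the limit of > 128000 nM in this assay, at which 4 of the 4 values shown sit. The compounds shown leave open whether any member of this series gives a measurable value in this assay, and what capping the ring nitrogen would then do.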